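Replacing 4-ethylcyclohexyl with iodo: a cytotoxicity estimate

A few compounds are considered here, and "the series" means these few. Any claim that something is new, unique, unknown or untested is made for them only; others in the source may bear on it.

Compound 1 `O=C(NC(=S)Nc1cccc(C(F)(F)F)c1)c1ccccc1`: > 100000 nM (a limit)
Compound 2 `CC[C@H]1CC[C@H](c2ccc(NC(=S)Nc3cccc(C(F)(F)F)c3)cc2)CC1`: 10000 nM

Going by the values given here, in an ADME assay on Vero 76 cells (Chlorocebus sabaeus) for cytotoxicity, read by crystal violet staining, with a stated time of 96 h (a lower number here means that less compound is tolerated, a higher number that more compound is tolerated), compound 2 gives 10000 nM, the only actual number so far. Compound 3 `FC(F)(F)c1cccc(NC(=S)Nc2ccc(I)cc2)c1`, not yet measured, carries iodo in place of 4-ethylcyclohexyl on an aromatic carbon. Among the compounds with values here, no measured pair shows what this swap does, so any expectation is tentative. It leans on compound 1, which also has no 4-ethylcyclohexyl and gives > 100000 nM, a limit of the assay and not a number. A moderate step beyond the scatter, towards more compound being tolerated, is expected: a 3.0-fold higher number from compound 2 to compound 3 (0.48 log units; beyond the scatter). For compound 3 the estimate is 30000 nM, with an expected range from 9000 nM to 100000 nM.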

Compound 3, half-maximal cytotoxic concentration: 9500 nM
The estimate for compound 3 lay 3.2-fold (0.50 log units) above the measured number, and the stated range covers the measured number.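

In this assay there is a 1.1-fold lower number from compound 2 to compound 3 (0.02 log units; within the scatter) when iodo takes the place of 4-ethylcyclohexyl. This first measured pair at this position shows that the ring-bearing group can give way to a single iodine atom without a shift beyond the scatter in how much compound the cells tolerate. Nothing available here explains this result.

From the compounds shown here alone, whether an amine or a carboxylic acid on this aromatic carbon would move the number stays open. So does whether any group at this position can move it at all.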